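A Methoxyphenyl Replaces a Chlorophenyl on the Ring Nitrogen

The source may report more compounds than this note shows. Statements on the series, on what has been measured and on what is new or still open speak of the compounds shown alone.

Compound 3 `S=c1oc(-c2ccc3c(c2)OCCO3)nn1CN1CCN(c2ccc(Cl)cc2)CC1` carries a 4-chlorophenyl on an amine nitrogen in a ring. In a functional assay on SW 1116 cells (Homo sapiens) for antiproliferative activity, read by MTT assay, with a stated time of 48 h (on this read-out higher numbers stand for weaker inhibition and lower numbers for stronger inhibition), compound 3 gives > 50000 nM, which is a limit of the assay and not a number. Compound 2 `Cc1ccc(N2CCN(Cn3nc(-c4ccc5c(c4)OCCO5)oc3=S)CC2)c(C)c1` likewise gives > 50000 nM, again a limit. Compound 1 `S=c1oc(-c2ccc3c(c2)OCCO3)nn1CN1CCN(C(c2ccccc2)c2ccccc2)CC1` reaches 21600 nM. The step that the two limits leave unreadable from compound 2 to compound 3 cannot be read, since both of its ends sit at the limit of > 50000 nM in this assay, at which 2 of the 3 values shown sit. Compound 4 `COc1ccccc1N1CCN(Cn2nc(-c3ccc4c(c3)OCCO4)oc2=S)CC1` differs from compound 3 by 2-methoxyphenyl in place of 4-chlorophenyl on an amine nitrogen in a ring. For the measured compounds named here, no readable measured step bears on this change, and the only plain number among the three is that of compound 1. The author therefore expects compound 4 to stay in the same weak region, with a step of an at least 1.2-fold lower number from compound 3 to compound 4 (0.09 log units; that floor lies within the scatter) expected to remain within the scatter. Compound 4 is estimated at 40000 nM, between 15000 nM and 100000 nM.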

Compound 4, half-maximal inhibitory concentration: 16900 nM
Compound 4: middle estimate off by 2.4-fold (0.37 log units), on the high side; measured number inside the range.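

In this assay, for the compounds shown here, a change on the amine nitrogen in a ring gives a readable step for the first time: 2-methoxyphenyl brings an at least 2.9-fold lower number from compound 3 to compound 4 (0.47 log units; beyond the scatter) and an at least 2.9-fold lower number from compound 2 to compound 4 (0.47 log units; beyond the scatter) in the same direction. As far as these compounds go, the true size of both steps stays open because compound 2 and compound 3 each sit at a limit: the limit of > 50000 nM in this assay, at which 2 of the 4 values shown sit. The compounds shown leave open whether the methoxy group itself matters, since a plain phenyl or a 2-hydroxyphenyl on this nitrogen does not appear among them. From the compounds shown here alone, whether a 2-ethoxyphenyl would lower the number further also remains open.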